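A larger ring on the sulfonyl sulfur of compound 3

This account rests on a few compounds, and the source may have more. Where it says the series, first, only, none or still open, it means among the compounds named here.

In a functional assay on A2780 cells (Homo sapiens) for antiproliferative activity, read by sulforhodamine B assay, with a stated time of 72 h (a lower number here means a stronger inhibitor, a higher number a weaker inhibitor), compound 3 `O=C(NCc1cccnc1)Nc1ccc(S(=O)(=O)N2CC3(COC3)C2)cc1` gives only a limit, > 2000 nM. Compound 1 `O=C(NCc1cnccn1)Nc1ccc(S(=O)(=O)c2ccccc2)cc1` also gives only a limit, > 2000 nM. The weak end of these data is therefore (the limit of > 2000 nM in this assay, at which 2 of the 3 values shown sit). Compound 2 `O=C(NCc1cccnc1)Nc1ccc(S(=O)(=O)N2C3CCC2COC3)cc1` gives a true number, 251 nM.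

Within the data shown here, the one measured step that changes the group on the sulfonyl sulfur is an at least 7.9-fold higher number from compound 2 to compound 3 (0.90 log units; beyond the scatter). It lies beyond the scatter, so a swap at this place can clearly shift the result in this assay.

Compound 4 `CC1CCN(S(=O)(=O)c2ccc(NC(=O)NCc3cccnc3)cc2)CCN1` has not been measured, and it changes that same place. Its structural difference is a group of 8 heavy atoms (6 carbon, 2 nitrogen; one seven-membered non-aromatic ring with 2 hetero atoms) in place of a group of 7 heavy atoms (5 carbon, 1 nitrogen, 1 oxygen; 2 four-membered non-aromatic rings with 1 hetero atom each), on a sulfonyl sulfur. The evidence is thin, because it rests on a single step, and neither group in that step is the one entering here. Compound 2, at 251 nM, shows that a group on the sulfonyl sulfur can bring a true number within reach, so some return towards a lower number seems likely. The expected change is an at least 2.8-fold lower number from compound 3 to compound 4 (0.45 log units; beyond the scatter), and this estimate remains uncertain. A limit result would be no surprise.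

For compound 4 the estimated value is 700 nM, with an expected range from 150 nM to 3000 nM.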

Compound 4, half-maximal inhibitory concentration: 109 nM
Estimate against measurement, compound 4: 6.4-fold (0.81 log units) above, and the stated range ends above it.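

In this assay, the group with one seven-membered ring brings back a true number on the sulfonyl sulfur, with an at least 18-fold lower number from compound 3 to compound 4 (1.26 log units; beyond the scatter), so a swap here can lower the number sharply as well as raise it. Compared with the only earlier true number, the change gives a 2.3-fold lower number from compound 2 to compound 4 (0.36 log units; beyond the scatter), a modest step that still lies beyond the usual scatter, so a second group at this place reaches a true number and goes somewhat further. The groups of 8 heavy atoms in compound 2 and compound 4 both give true numbers while the group of 7 heavy atoms in compound 3 does not, but three compounds are too few to make this a rule, and ring shape and atom types change along with size.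

As far as these compounds go, how weak the weak end really is stays unknown: the limit of > 2000 nM in this assay, at which 2 of the 4 values shown sit. From the compounds shown here alone, it also stays open whether the gain follows ring size or the second ring nitrogen with its hydrogen-bond donor, and a morpholine ring or a simple dimethylamino group on the same sulfur would help to separate the two.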